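A few compounds are considered here, and "the series" means these few. Any claim that something is new, unique, unknown or untested is made for them only; others in the source may bear on it.

Measured so far:
compound 1, `O=c1nc(N2CCC3(CCN(Cc4ccc(C(F)(F)F)cc4)CC3)CC2)sc2c([N+](=O)[O-])cc(C(F)(F)F)cc12`, 145000 nM in an ADME assay on Vero cells (Chlorocebus sabaeus) for cytotoxicity, read by MTT assay, with a stated time of 72 h; a higher number here means that more compound is tolerated, a lower number that less compound is tolerated;
compound 2, `O=c1nc(N2CCC3(CCN(Cc4cc(F)cc(F)c4)CC3)CC2)sc2c([N+](=O)[O-])cc(C(F)(F)F)cc12`, 1170000 nM in this assay.

Compound 2 gives the highest of the two numbers, and the step of an 8.1-fold higher number from compound 1 to compound 2 (0.91 log units; beyond the scatter) is the only one measured. Compound 3, `O=c1nc(N2CCC3(CCN(Cc4cccc(F)c4)CC3)CC2)sc2c([N+](=O)[O-])cc(C(F)(F)F)cc12`, differs from compound 2 by hydrogen in place of fluoro on an aromatic carbon. For the measured compounds named here, no measured step shares this change; the one step known concerns a different substituent pattern, so it bears on compound 3 only loosely. A move of roughly that size, or none beyond the scatter, is expected in this assay, with a slightly lower number thought more likely. Compound 3 is therefore estimated at 700000 nM, between 250000 nM and 2000000 nM, a step of a 1.7-fold lower number from compound 2 to compound 3 (0.22 log units; within the scatter).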

Compound 3, half-maximal cytotoxic concentration in the Vero assay: 1400000 nM
Estimate against measurement, compound 3: 2.0-fold (0.30 log units) below, and the stated range covers the measured number.
By their numbers in the Vero assay, from the lowest: compound 1; then compounds 2 and 3 (each within the scatter of the next).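

In the Vero assay the second fluoro of the 3,5-difluorobenzyl group can be replaced by hydrogen with no change beyond the scatter, as shown by a 1.2-fold higher number from compound 2 to compound 3 (0.08 log units; within the scatter) and the higher number over the 4-(trifluoromethyl)phenyl group also holds with a single fluoro, as shown by a 9.7-fold higher number from compound 1 to compound 3 (0.98 log units; beyond the scatter) in the same assay. In a physicochemical assay for solubility, read by HPLC, with a stated time of 12 h, at pH 2 (on this read-out lower numbers stand for lower solubility and higher numbers for higher solubility), compound 2 gives 0.67 ug/mL and compound 3 gives 1.13 ug/mL on the same change, which is a 1.7-fold higher number from compound 2 to compound 3 (0.23 log units; within the scatter) on this read-out. No measurement shown here accounts for either result.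

From the compounds shown here alone, it stays open whether an amine or a carboxylic acid in place of the remaining fluoro of the 3-fluorobenzyl group would leave both read-outs as they are.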